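Working notes: from compound 2 to compound 3

The source may report more compounds than this note shows. Statements on the series, on what has been measured and on what is new or still open speak of the compounds shown alone.

Values so far in a functional assay on UACC-62 cells (Homo sapiens) for antiproliferative activity, read by sulforhodamine B assay, with a stated time of 48 h (on this read-out higher numbers stand for weaker inhibition and lower numbers for stronger inhibition), are:
- compound 1 `C/C=C(\C)C(=O)O[C@H]1C=CC(=O)O[C@H]1CCC(=O)[C@H](C)O` at 24000 nM
- compound 2 `C/C=C(\C)C(=O)O[C@H]1C=CC(=O)O[C@H]1COC(=O)[C@H](C)O` at 13000 nM

Compound 2 stands at 13000 nM with one measured neighbour. Compound 3 `C/C=C(\C)C(=O)O[C@H]1C=CC(=O)O[C@H]1CNC(=O)[C@H](C)O` carries ((1-hydroxyethyl)carbonyl)amino in place of ((1-hydroxyethyl)carbonyl)oxy on a saturated chain carbon bound to a saturated ring carbon. For the measured compounds named here, the only measured step bearing on this (a 1.8-fold lower number from compound 1 to compound 2 (0.27 log units; within the scatter)) put ((1-hydroxyethyl)carbonyl)oxy in place of ((1-hydroxyethyl)carbonyl)methyl and stayed within the scatter. No step beyond the scatter is therefore expected in this assay, and the estimated step is a 1.2-fold higher number from compound 2 to compound 3 (0.06 log units; within the scatter) in either direction. Compound 3 is expected at 15000 nM with an estimated range of 6000 nM to 35000 nM for now.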

Compound 3, half-maximal inhibitory concentration: 28000 nM
For compound 3 the middle estimate is 1.9-fold (0.27 log units) below the measured one; the range from low to high includes it.
By their numbers in this assay, from the lowest: compounds 2, 1 and 3 (each within the scatter of the next, the first and the last beyond it).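

In this assay this position now shows a step beyond the scatter: ((1-hydroxyethyl)carbonyl)amino in place of ((1-hydroxyethyl)carbonyl)oxy gives a 2.2-fold higher number from compound 2 to compound 3 (0.33 log units; beyond the scatter) on a saturated chain carbon bound to a saturated ring carbon. The same amino group in place of ((1-hydroxyethyl)carbonyl)methyl gives a 1.2-fold higher number from compound 1 to compound 3 (0.07 log units; within the scatter), so the position separates only the oxy and amino forms so far. Nothing at hand accounts for the step.

Open, from the compounds shown here alone, is how a carboxylic acid, an amine or a longer chain would read on the same saturated chain carbon.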